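Methoxy for Chloro on the Benzyl Amide

The compounds below may be only part of what the source reports. "The series", "measured", "known", "first", "only" and "open" are said of these compounds alone.

In a functional assay on HepG2 cells (Homo sapiens) for cytotoxicity, read by MTT assay, with a stated time of 48 h (a higher number here means a weaker inhibitor, a lower number a stronger inhibitor), compound 3 `COc1ccccc1C(=O)Nc1ccc2nc(SCC(=O)NCc3ccc(Cl)cc3)sc2c1` gives 600 nM. In this assay compound 2 `COc1ccccc1C(=O)Nc1ccc2nc(SCC(=O)NCc3ccccc3)sc2c1` gives 8000 nM. In this assay compound 1 `COc1ccc(CNC(=O)CSc2nc3ccc(NC(=O)c4ccc([N+](=O)[O-])cc4)cc3s2)cc1` reaches only > 100000 nM, which is a limit of the assay and not a number.

Among the two numbers, compound 3 stands lowest: its nearest neighbour is compound 2, and the one measured step, a 13-fold lower number from compound 2 to compound 3 (1.12 log units; beyond the scatter), shows how much the group on the benzyl ring matters in this series. Compound 4 `COc1ccc(CNC(=O)CSc2nc3ccc(NC(=O)c4ccccc4OC)cc3s2)cc1` keeps the whole frame of compound 3 and differs only in methoxy in place of chloro on an aromatic carbon.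

Among the measured compounds shown here, no measured step swaps chloro for methoxy directly. The step from compound 2 to compound 3 shows that a change at this position can move the number far beyond the scatter, in either direction. Compound 1 carries the same methoxybenzyl group as compound 4 and sits at the limit (the limit of > 100000 nM in this assay, at which 1 of the 3 values shown sits), but it also carries a different benzamide, so its two values with compound 3 cannot be separated into one cause. A moderate rise in the number is therefore expected, somewhere between the values of compound 3 and compound 2. Compound 4 is estimated at 3000 nM, with a range from 600 nM to 20000 nM. The expected step is a 5.0-fold higher number from compound 3 to compound 4 (0.70 log units; beyond the scatter).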

Compound 4, half-maximal inhibitory concentration: 2100 nM
Beside the measured number, compound 4's estimate is 1.4-fold (0.15 log units) above it, and the stated range covers the measured number.
By their numbers in this assay, from the lowest: compound 3; then compound 4; then compound 2. At a limit, above all of these: compound 1.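

With the direct swap on the benzyl ring now in hand, 4-chlorobenzyl to 4-methoxybenzyl gives in this assay a 3.5-fold higher number from compound 3 to compound 4 (0.54 log units; beyond the scatter), so this change costs far less than removing the chloro altogether. Methoxy in place of hydrogen gives a 3.8-fold lower number from compound 2 to compound 4 (0.58 log units; beyond the scatter), which means that among the three compounds sharing the 2-methoxyphenyl amide, both substituted benzyl groups carry lower numbers than the plain benzyl group, with chloro lowest and each step beyond the scatter. The other end of the molecule proves to count as well: with the 4-methoxybenzyl group held fixed, 2-methoxyphenyl in place of 4-nitrophenyl on a carbonyl carbon gives an at least 47-fold lower number from compound 1 to compound 4 (1.67 log units; beyond the scatter), a step whose size rests on compound 1, which stands at a limit and not at a number: the limit of > 100000 nM in this assay, at which 1 of the 4 values shown sits.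

On these data alone, whether the order of chloro, methoxy and hydrogen on the benzyl ring would hold with the 4-nitrophenyl amide in place of the 2-methoxyphenyl amide stays open. Also open is where a dimethylamino group or a carboxylic acid on the same aromatic carbon would fall, and the three groups compared here cannot say why their numbers stand in this order.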